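Solubility series: compound 1 to compound 4

A few compounds are considered here, and "the series" means these few. Any claim that something is new, unique, unknown or untested is made for them only; others in the source may bear on it.

Compound 1 `CN1CCN(C[C@H]2CN(c3ccc(-n4cc(-c5ccccn5)cn4)c(F)c3)C(=O)O2)CC1` is the parent of this set. In a physicochemical assay for solubility, read by HPLC, with a stated time of 24 h (on this read-out lower numbers stand for lower solubility and higher numbers for higher solubility), compound 1 gives 1690000 nM, the highest of the three numbers measured. Compound 2 `CCC(=O)NC[C@H]1CN(c2ccc(-n3cc(-c4ccccn4)cn3)c(F)c2)C(=O)O1` gives 147000 nM and compound 3 `O=CNC[C@H]1CN(c2ccc(-n3cc(-c4ccccn4)cn3)c(F)c2)C(=O)O1` gives 217000 nM; the step of a 1.5-fold higher number from compound 2 to compound 3 (0.17 log units; within the scatter) is within the scatter, whereas an 11-fold lower number from compound 1 to compound 2 (1.06 log units; beyond the scatter) and a 7.8-fold lower number from compound 1 to compound 3 (0.89 log units; beyond the scatter) both lie beyond it. Compound 4 `CN(C)S(=O)(=O)NC[C@H]1CN(c2ccc(-n3cc(-c4ccccn4)cn3)c(F)c2)C(=O)O1` is not yet measured; the change from compound 1 is (dimethylsulfamoyl)amino in place of 4-methylpiperazin-1-yl on a saturated chain carbon bound to a saturated ring carbon. The two measured steps from compound 1, both exchanges of the same group at the same place, point the same way, so a lowering of similar size is expected: for compound 4 the estimated step is a 9.4-fold lower number from compound 1 to compound 4 (0.97 log units; beyond the scatter). In this assay compound 4 is expected to give 180000 nM, within a range of 75000 nM to 430000 nM.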

Compound 4, solubility: 472000 nM
For compound 4 the middle estimate is 2.6-fold (0.42 log units) below the measured one; the measured number lies above the stated range.
By their numbers in this assay, from the lowest: compounds 2 and 3 (each within the scatter of the next); then compound 4; then compound 1.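

On this saturated chain carbon, the exchange of 4-methylpiperazin-1-yl does not have a fixed size in this assay: with (dimethylsulfamoyl)amino, a 3.6-fold lower number from compound 1 to compound 4 (0.55 log units; beyond the scatter) is a smaller step than those to the formylamino and propanoylamino compounds. What sits on the amine nitrogen matters, as a 2.2-fold higher number from compound 3 to compound 4 (0.34 log units; beyond the scatter) and a 3.2-fold higher number from compound 2 to compound 4 (0.51 log units; beyond the scatter) both separate dimethylsulfamoyl from the two acyl groups, which themselves stay within the scatter of each other. Nothing available gives a reason for this order. Open, from the compounds shown here alone, is whether an open-chain dimethylamino group or a carboxylic acid at this place would come closer to compound 1. Also open, going by these compounds, is whether longer chains on the sulfamoyl nitrogen would keep the number of compound 4.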